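This account rests on a few compounds, and the source may have more. Where it says the series, first, only, none or still open, it means among the compounds named here.

Compound 3, whose structure is `COc1cc(-c2nnc(SCC(=O)c3ccccc3C)n2N2C(=O)c3ccccc3C2=O)cc(OC)c1OC`, sits at the top of this small set: in a functional assay on HepG2 cells (Homo sapiens) for cytotoxicity, read by MTT assay, with a stated time of 48 h (a lower number here means a stronger inhibitor, a higher number a weaker inhibitor), compound 3 gives > 200000 nM, which is a limit of the assay rather than a number. Compound 1, with the structure `C#CCSc1nnc(-c2cc(OC)c(OC)c(OC)c2)n1N1C(=O)c2ccccc2C1=O`, likewise gives > 200000 nM in this assay, again a limit. Only compound 2, the structure `COc1cc(-c2nnc(SCC(=O)c3ccc(Cl)cc3)n2N2C(=O)c3ccccc3C2=O)cc(OC)c1OC`, returns a measured number: in this assay compound 2 gives 22000 nM. The two limits leave the step from compound 1 to compound 3 unreadable, and the limit of > 200000 nM in this assay, at which 2 of the 3 values shown sit, is where both of those values rest.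

Compound 4, the structure `COc1cc(-c2nnc(SCC(=O)c3ccc(F)cc3)n2N2C(=O)c3ccccc3C2=O)cc(OC)c1OC`, differs from compound 3 in one place, (4-fluorophenyl in place of 2-methylphenyl on a carbonyl carbon). The measured step that bears most directly on it is the one running the other way, from a 4-chlorophenyl to a 2-methylphenyl on the same carbonyl carbon: an at least 9.0-fold higher number from compound 2 to compound 3 (0.95 log units; beyond the scatter). Returning the phenyl to a 4-halogen pattern, here with fluorine in place of chlorine, would be expected to undo at least part of that rise, though no measured pair shows fluorine against chlorine. Compound 4 is therefore estimated to return a number below the limit, giving an expected 50000 nM with a range from 15000 nM to 200000 nM, which is the expected step of an at least 4.0-fold lower number from compound 3 to compound 4 (0.60 log units; beyond the scatter).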

Compound 4, half-maximal inhibitory concentration: > 200000 nM
Compound 4: a limit, no number; the forecaster's own chance of this, stated with the estimate: 40%; at least 4.0-fold (0.60 log units) between middle value and limit.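

In this assay, going by these compounds alone, fluoro in place of chloro on an aromatic carbon, the only change between the two compounds, gives an at least 9.0-fold higher number from compound 2 to compound 4 (0.95 log units; beyond the scatter). The earlier compounds tied the one measured number to a 4-chlorophenyl but could not show whether another halogen in the same pattern would keep it; among the compounds shown, the 4-fluorophenyl does not, and compound 2 remains the only one with a number. The steps from compound 3 to compound 4 and from compound 1 to compound 4 cannot be read, so the 4-fluorophenyl and the 2-methylphenyl on the carbonyl carbon cannot be told apart, and the set gathers at a single point: the limit of > 200000 nM in this assay, at which 3 of the 4 values shown sit.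

As far as these compounds go, what remains open is how far compound 1, compound 3 and compound 4 lie beyond that limit, and so whether any real difference separates them. From the compounds shown here alone, it is also open whether a 4-bromophenyl or an unsubstituted phenyl on the same carbonyl carbon would return a number, which would show whether the value of compound 2 is specific to the 4-chlorophenyl.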